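The compounds below may be only part of what the source reports. "The series", "measured", "known", "first", "only" and "open" are said of these compounds alone.

In a functional assay on HepG2 cells (Homo sapiens) for antiproliferative activity, read by MTT assay, with a stated time of 24 h (on this read-out lower numbers stand for stronger inhibition and higher numbers for weaker inhibition), compound 1 `Cc1ccc(-c2nn(-c3ccccc3)cc2-c2nc3ccccc3n2S(=O)(=O)c2ccc(C(F)(F)F)cc2)cc1` gives 1930 nM, while compound 2 `O=S(=O)(c1ccccc1)n1c(-c2cn(-c3ccccc3)nc2-c2ccc(F)cc2)nc2ccccc21` gives 720 nM. That is the lower of the two numbers, and the gap lies beyond the usual scatter. Compound 3 `O=S(=O)(c1ccc(Cl)cc1)n1c(-c2cn(-c3ccccc3)nc2-c2ccc(F)cc2)nc2ccccc21` differs from compound 2 in one place: chloro in place of hydrogen on an aromatic carbon, turning phenylsulfonyl into (4-chlorophenyl)sulfonyl (chloro in place of hydrogen on an aromatic carbon). For the measured compounds named here, no measured pair shows this change on its own, so no step beyond the scatter is expected in this assay. For compound 3 the estimated value is 800 nM, with an expected range from 300 nM to 2000 nM. The expected change is a 1.1-fold higher number from compound 2 to compound 3 (0.05 log units; within the scatter).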

Compound 3, half-maximal inhibitory concentration: 4230 nM
Compound 3: the middle estimate sits 5.3-fold (0.72 log units) below what was measured; the measured number lies above the stated range.
By their numbers in this assay, from the lowest: compound 2; then compound 1; then compound 3.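

Turning phenylsulfonyl into (4-chlorophenyl)sulfonyl gives a 5.9-fold higher number from compound 2 to compound 3 (0.77 log units; beyond the scatter) in this assay, the first direct reading of this change. It means weaker inhibition, so this position on the ring responds clearly to a single added chlorine atom. Nothing available here explains why the number rises.

On these data alone, it remains open whether a smaller or different group at the same place, such as a methoxy group or an amine, would also weaken inhibition. Whether chloro would have the same effect on another carbon of this ring is also unknown.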